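Chloromethyl Extension of an Acetylated Pyrazoline Core

The source may report more compounds than this note shows. Statements on the series, on what has been measured and on what is new or still open speak of the compounds shown alone.

Of the compounds shown here, three built on a shared core have been measured in a functional assay on HCC1806 cells (Homo sapiens) for inhibition, read by sulforhodamine B assay, tested at 10 uM; a lower number here means less inhibition, a higher number more inhibition at the concentration tested (going by the name of the read-out). Compound 1 `CN(C)c1ccc(C2CC(c3ccc(-n4ccnc4)cc3)=NN2)cc1` gives -20.9%. Compound 2 `CN(C)c1ccc(C2CC(c3ccc(-n4cncn4)cc3)=NN2C(=O)CCCl)cc1` gives -3.4%. Among the compounds with values here, compound 3 `CC(=O)N1N=C(c2ccc(-n3ccnc3)cc2)CC1c1ccc(N(C)C)cc1` gives -9.7%, which places it second of the three numbers: it lies within the scatter of compound 2, and it stands beyond the scatter from compound 1, the single measured step of a number 11.2 percentage points higher from compound 1 to compound 3 (beyond the scatter) being the only one that differs in one place. That step concerns the acyl group on the ring nitrogen.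

Compound 4 `CN(C)c1ccc(C2CC(c3ccc(-n4ccnc4)cc3)=NN2C(=O)CCCl)cc1` has not yet been measured. It differs from compound 3 by chloromethyl in place of hydrogen on a saturated chain carbon bound to a carbonyl carbon. Within the data shown here, no measured step covers this particular change; the acylation step from compound 1 to compound 3 is the closest relative, and it was of modest size. Compound 2, which carries the same (2-chloroethyl)carbonyl group on a different aryl substituent, gives a number that sits within the scatter of compound 3, so no shift beyond the scatter is indicated.

Compound 4 is therefore expected to give about -5% in this assay, between -20% and 10%. The expected step of a number 4.7 percentage points higher from compound 3 to compound 4 (within the scatter) is estimated to remain within the usual scatter.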

Compound 4, a percentage reported as inhibition, at one concentration (the size of the read-out at that concentration, not a potency): -5.2%
Beside the measured number, compound 4's estimate is 0.2 percentage points above it; measured number inside the range.
By their numbers in this assay, from the lowest: compound 1; then compounds 3, 4 and 2 (each within the scatter of the next).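

In this assay, chloromethyl in place of hydrogen on a saturated chain carbon bound to a carbonyl carbon, which turns acetyl into (2-chloroethyl)carbonyl, gives a number 4.5 percentage points higher from compound 3 to compound 4 (within the scatter) and so adds no readable change at this position. Within the data shown here, with (2-chloroethyl)carbonyl held constant, 1H-imidazol-1-yl in place of 1H-1,2,4-triazol-1-yl on an aromatic carbon gives a number 1.8 percentage points lower from compound 2 to compound 4 (within the scatter) as the first direct reading of that exchange, and it too shows no difference that can be told from the scatter. Against the free ring nitrogen, (2-chloroethyl)carbonyl gives a number 15.7 percentage points higher from compound 1 to compound 4 (beyond the scatter) and thus joins acetyl, which gave a number 11.2 percentage points higher from compound 1 to compound 3 (beyond the scatter) as a second acyl group with a step beyond the scatter, though only these two acyl groups on this core can be read in this way.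

No measured evidence given here accounts for any of these differences. The compounds shown leave open whether the chlorine itself contributes, which a propanoyl group on the same ring nitrogen would address, and what an amine or a carboxylic acid at the end of the chain, or a longer chain, would do to the reading.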